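The source may report more compounds than this note shows. Statements on the series, on what has been measured and on what is new or still open speak of the compounds shown alone.

The measured compounds in a functional assay on HeLa cells (Homo sapiens) for cytotoxicity, read by WST assay, with a stated time of 48 h; on this read-out lower numbers stand for stronger inhibition and higher numbers for weaker inhibition:
- compound 1 `CCCCCC/C=C/C[C@H]1C[C@@H]([C@@H](O)c2ccccc2)CO[C@@H]1c1ccccc1` gives 7400 nM
- compound 2 `COc1cccc(/C=C/C[C@@H]2C[C@@H]([C@@H](O)c3ccc(OC)c(OC)c3)CO[C@H]2c2ccc(OC)c(OC)c2)c1` gives 16400 nM
- compound 3 `COc1ccc(CCC[C@@H]2C[C@@H]([C@@H](O)c3ccc(OC)c(OC)c3)CO[C@H]2c2ccc(OC)c(OC)c2)cc1OC` gives 35700 nM

Compound 1 stands lowest of the three numbers; compound 2 is nearest to it and compound 3 furthest. Compound 4 `O[C@@H](c1ccccc1)[C@H]1CO[C@H](c2ccccc2)[C@@H](C/C=C/C2CCCC2)C1` differs from compound 1 in one place: cyclopentyl in place of hexyl on a double-bonded chain carbon bound to a double-bonded chain carbon. Among the compounds with values here, the only measured step, a 2.2-fold higher number from compound 2 to compound 3 (0.34 log units; beyond the scatter), concerns a different part of the side chain and a different substitution, so it bears only loosely on the cyclopentyl for hexyl exchange; it shows that changes in that chain move this assay modestly. Compound 4 is therefore expected to give a number close to compound 1, with the step of a 1.2-fold higher number from compound 1 to compound 4 (0.09 log units; within the scatter) expected to lie near the scatter. The estimate for compound 4 is 9000 nM, between 3500 nM and 24000 nM.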

Compound 4, half-maximal inhibitory concentration: 9330 nM
Estimate against measurement, compound 4: 1.0-fold (0.02 log units) below, within the range that was stated.
By their numbers in this assay, from the lowest: compounds 1, 4 and 2 (each within the scatter of the next, the first and the last beyond it); then compound 3.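

In this assay, the exchange of hexyl for cyclopentyl on a double-bonded chain carbon bound to a double-bonded chain carbon gives a 1.3-fold higher number from compound 1 to compound 4 (0.10 log units; within the scatter). Within the data shown here, the number thus stays within the scatter when a five-membered carbon ring replaces the open chain at this place, something the earlier compounds did not show. No measurement given here offers an explanation for this result. On these data alone, it remains open whether an amine, a carboxylic acid or a longer chain at this place would also leave the number of compound 1 within the scatter.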